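The source may hold more compounds than are shown below. What is called first, only, known or untested is meant among the compounds shown, and "the series" means these compounds.

Measured so far in an assay on isolated protein for binding affinity to Equilibrative nucleoside transporter 1 (Homo sapiens); a lower number here means a stronger inhibitor, a higher number a weaker inhibitor:
compound 1 `Cc1cc(C)c(SCc2ncnc3c2ncn3[C@@H]2O[C@H](CO)[C@@H](O)[C@H]2O)c(C)c1`, 33100 nM
compound 2 `OC[C@H]1O[C@@H](n2cnc3c(CSc4ccc(Cl)c(Cl)c4)ncnc32)[C@H](O)[C@@H]1O`, 224 nM
compound 3 `OC[C@H]1O[C@@H](n2cnc3c(CSc4cccc(I)c4)ncnc32)[C@H](O)[C@@H]1O`, 245 nM

Compound 3 stands second highest of the three numbers, indistinguishable from compound 2 (a 1.1-fold higher number from compound 2 to compound 3 (0.04 log units; within the scatter)) and far from compound 1 (a 140-fold lower number from compound 1 to compound 3 (2.13 log units; beyond the scatter)). Next is compound 4 `N#Cc1ccc(SCc2ncnc3c2ncn3[C@@H]2O[C@H](CO)[C@@H](O)[C@H]2O)cc1`, which differs from compound 3 by 4-cyanophenyl in place of 3-iodophenyl on a sulfur. Among the compounds with values here, no measured step exchanges an iodophenyl for a cyanophenyl, so there is no direct precedent. Within the data shown here, the one exchange between two substituted phenyl rings that avoids the trimethyl case is a 1.1-fold higher number from compound 2 to compound 3 (0.04 log units; within the scatter), within scatter, whereas a 150-fold lower number from compound 1 to compound 2 (2.17 log units; beyond the scatter) shows that the ring on the sulfur can shift the number greatly. For compound 4 the expected step is a 2.0-fold higher number from compound 3 to compound 4 (0.31 log units; beyond the scatter), a modest weakening, with wide uncertainty. Compound 4 is therefore estimated at 500 nM, in the range 150 nM to 2000 nM.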

Compound 4, half-maximal inhibitory concentration: 81.3 nM
Beside the measured number, compound 4's estimate is 6.2-fold (0.79 log units) above it, and the stated range ends above it.
By their numbers in this assay, from the lowest: compound 4; then compounds 2 and 3 (each within the scatter of the next); then compound 1.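

With a 4-cyanophenyl on the sulfur, this position separates rings that compounds 2 and 3 left level: a 3.0-fold lower number from compound 3 to compound 4 (0.48 log units; beyond the scatter) and a 2.8-fold lower number from compound 2 to compound 4 (0.44 log units; beyond the scatter) are both beyond the scatter. The full span at this position also widens, with a 410-fold lower number from compound 1 to compound 4 (2.61 log units; beyond the scatter) as the largest step in the set. No measurement on hand explains these steps.
As far as these compounds go, whether the nitrile itself or the substitution pattern of the ring carries the gain stays open. Also open, from the compounds shown here alone, is how an amine or a carboxylic acid in place of the nitrile would behave.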